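This account rests on a few compounds, and the source may have more. Where it says the series, first, only, none or still open, it means among the compounds named here.

Measured so far in an assay on CHO cells for displacement of a labelled ligand from transient receptor potential cation channel subfamily V member 1 (Rattus norvegicus), read by scintillation counting, with a stated time of 60 min; a lower number here means a stronger inhibitor, a higher number a weaker inhibitor:
compound 1, `CC(C(=O)NCc1ccc(C(C)(C)C)cc1)c1ccc(NS(C)(=O)=O)c(Cl)c1`, 30.7 nM;
compound 2, `CC(C(=O)NCc1ccc(C(C)(C)C)cc1)c1ccc(NS(C)(=O)=O)c(C#N)c1`, 344 nM.

Compound 2 gives the highest of the two numbers; its nearest neighbour is compound 1, with an 11-fold higher number from compound 1 to compound 2 (1.05 log units; beyond the scatter). Compound 3, `CC(C(=O)NCc1ccc(C(C)(C)C)cc1)c1ccc(NS(C)(=O)=O)c(N2CCCCC2)c1`, differs from compound 2 by piperidin-1-yl in place of cyano on an aromatic carbon. Within the data shown here, no measured step covers piperidin-1-yl; the only step that bears on this position is the one from compound 1 to compound 2, which was large. Because of an 11-fold higher number from compound 1 to compound 2 (1.05 log units; beyond the scatter) the position is treated as sensitive, and a return toward the number of compound 1 is expected, with wide uncertainty. Compound 3 is therefore expected at 150 nM, range 30 nM to 800 nM. This expected step, a 2.3-fold lower number from compound 2 to compound 3 (0.36 log units; beyond the scatter), is a guess rather than an extrapolation.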

Compound 3, inhibition constant: "active" (no number reported)
Compound 3 has no reported number here, so the estimate cannot be set against anything.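

Among these compounds, compound 3 is reported only as active, without a number, so no step from compound 2 to compound 3 can be read. The compounds shown leave open how piperidin-1-yl ranks against cyano and chloro at this position. No evidence bears on this result.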